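The compounds below may be only part of what the source reports. "The series", "measured", "known", "first", "only" and "open" are said of these compounds alone.

In a functional assay on MT4 cells (Homo sapiens) for cytotoxicity (on this read-out higher numbers stand for weaker inhibition and lower numbers for stronger inhibition), compound 2 `CCCCOc1cc(C)cc(S(=O)(=O)c2cccc(N)c2C#N)c1` gives > 2000 nM, which is a limit and not a number. Compound 3 `N#Cc1cccc(S(=O)(=O)c2cccc(N)c2C#N)c1` gives > 200000 nM, and this is also a limit. On these data alone, only compound 1 `N#Cc1c(N)cccc1Sc1ccccc1Cl` has an actual number, 33000 nM, so the exact standing of compound 2 remains open. Compound 4 `COc1cc(C)cc(S(=O)(=O)c2cccc(N)c2C#N)c1` has hydrogen in place of propyl on a saturated chain carbon bound to an oxygen on an aromatic ring, (hydrogen in place of propyl on a saturated chain carbon bound to an oxygen on an aromatic ring), turning butoxy to methoxy. The expectation leans on compound 1 at 33000 nM. A sizeable expected move towards weaker inhibition is a step that the limit leaves unreadable from compound 2 to compound 4, beyond the usual scatter. For compound 4, the estimated value is 40000 nM, with an expected range from 6000 nM to 200000 nM.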

Compound 4, half-maximal inhibitory concentration: 94000 nM
Beside the measured number, compound 4's estimate is 2.4-fold (0.37 log units) below it, within the range that was stated.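

Compound 2 has only a limit and not a number, and the step from compound 2 to compound 4 cannot be read. The compounds shown leave open how much changing butoxy to methoxy shifts the inhibition.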